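The source may report more compounds than this note shows. Statements on the series, on what has been measured and on what is new or still open speak of the compounds shown alone.

In an assay on microsomes from liver for inhibition of sterol O-acyltransferase 1 (Rattus norvegicus), tested at 50 ug/mL (a higher number here means more inhibition at the concentration tested (going by the name of the read-out), a lower number less inhibition), compound 1, with the structure `CCCCCCCN(CCCCCSc1cc(-c2ccccc2)cnn1)C(=O)Nc1ccc(F)cc1F`, gives 75%. Compound 2, with the structure `CCCCCCCN(CCCCC[S+]([O-])c1cc(-c2ccccc2)c(-c2ccccc2)nn1)C(=O)Nc1ccc(F)cc1F`, gives 65% in this assay, and compound 3, with the structure `CCCCCCCN(CCCCC[S+]([O-])c1cc(-c2ccccc2)cnn1)C(=O)Nc1ccc(F)cc1F`, gives 62%. The number for compound 3 is the lowest of the three, but its gap to compound 2 is within the scatter, while its gap to compound 1 is beyond it. Among the measured compounds shown here, the one step that has been measured, a number 3 percentage points lower from compound 2 to compound 3 (within the scatter), exchanges a phenyl on an aromatic carbon for a hydrogen and leaves the read-out essentially unchanged.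

Compound 4 has the structure `CCCCCCCN(CCCCC[S+]([O-])c1ccc(-c2ccccc2)nn1)C(=O)Nc1ccc(F)cc1F`. It differs from compound 3 in this way: a group of 12 heavy atoms (10 carbon, 2 nitrogen; one six-membered aromatic ring of carbon only, one six-membered aromatic ring with 2 hetero atoms) in place of a group of 12 heavy atoms (10 carbon, 2 nitrogen; one six-membered aromatic ring of carbon only, one six-membered aromatic ring with 2 hetero atoms), on a sulfur. The two compounds have the same atoms, joined differently; the group that enters, 6-phenylpyridazin-3-yl, sits on a sulfur whose other neighbours are an oxygen and a saturated chain carbon. For the measured compounds named here, the step from compound 2 to compound 3 is the only measured guide, and it shows that moving or removing a phenyl on this ring changed the read-out by a small amount within the scatter. A step of no more than the scatter is therefore expected here too.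

For compound 4 the expected value in this assay is 62%, within a range from 45% to 78%. The expected step is no change at the digits printed from compound 3 to compound 4 (within the scatter).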

Compound 4, a percentage reported as inhibition, at one concentration (the size of the read-out at that concentration, not a potency): 55%
Estimate against measurement, compound 4: 7 percentage points above; the measured number falls inside the stated range.
By their numbers in this assay, from the lowest: compounds 4, 3, 2 and 1 (each within the scatter of the next, the first and the last beyond it).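

In this assay, joining the same atoms differently, so that the group on the sulfur becomes 6-phenylpyridazin-3-yl, gives a number 7 percentage points lower from compound 3 to compound 4 (within the scatter), so this read-out does not separate the two arrangements. Compound 2 carries two phenyl groups on its ring, and compound 4 now completes the pair of single removals: hydrogen in place of one phenyl gives a number 3 percentage points lower from compound 2 to compound 3 (within the scatter), and hydrogen in place of the other gives a number 10 percentage points lower from compound 2 to compound 4 (within the scatter), which shows that neither removal on its own moves the number beyond the scatter. No measurement at hand offers an explanation for these numbers.

Going by these compounds, it remains open whether the steps stay this size with something other than phenyl on that ring, such as an amine or a carboxylic acid, or with hydrogen in place of both phenyl groups. Also open, on these data alone, is how a compound with the 6-phenylpyridazin-3-yl group would read if its sulfur carried no oxygen, as the sulfur of compound 1 does not.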